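A few compounds are considered here, and "the series" means these few. Any claim that something is new, unique, unknown or untested is made for them only; others in the source may bear on it.

Series notes. Among the compounds with values here, in a functional assay on HEK293 cells for activation of melanin-concentrating hormone receptor 1 (Homo sapiens), read by inositol phosphate accumulation (on this read-out higher numbers stand for an effect only at larger amounts of compound and lower numbers for an effect already at smaller amounts), compound 1 `CC(C)(C)c1cc(N)c2cc(NC(=O)/C=C/c3ccc(C(F)(F)F)cc3)ccc2n1` gives 29 nM, the lowest of the three numbers so far; compound 3 `CCCc1cc(N)c2cc(NC(=O)/C=C/c3ccc(F)cc3)ccc2n1` gives 200 nM and compound 2 `CCCc1cc(N2CCCC2)c2cc(NC(=O)/C=C/c3ccc(C(F)(F)F)cc3)ccc2n1` gives 2800 nM, and both gaps to compound 1 lie beyond the scatter. Compound 4 `Cc1cc(N)c2cc(NC(=O)/C=C/c3ccc(C(F)(F)F)cc3)ccc2n1` has not yet been measured. It differs from compound 1 by methyl in place of tert-butyl on an aromatic carbon. Within the data shown here, no pair of measured compounds differs by this exchange alone, and compound 3 changes two sites at once relative to compound 1, so the size of the step is not readable from the data. The step from compound 1 to compound 4 is expected to be a 3.4-fold higher number from compound 1 to compound 4 (0.54 log units; beyond the scatter), a moderate loss beyond the scatter. Compound 4 is estimated at 100 nM, with a range from 30 nM to 400 nM.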

Compound 4, half-maximal effective concentration: 140 nM
Compound 4: the middle estimate sits 1.4-fold (0.15 log units) below what was measured, within the range that was stated.
By their numbers in this assay, from the lowest: compound 1; then compounds 4 and 3 (each within the scatter of the next); then compound 2.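

In this assay, within the data shown here, methyl in place of tert-butyl on an aromatic carbon next to the ring nitrogen gives a 4.8-fold higher number from compound 1 to compound 4 (0.68 log units; beyond the scatter) and is the first exchange at this position that can be read alone. In this one pair, the change from tert-butyl to methyl costs a modest step while leaving the rest of compound 1 unchanged. Nothing measured on this series bears on the cause of this step.

Going by these compounds, whether ethyl or isopropyl at this position would give a number nearer compound 1 or compound 4 remains open. Compounds 2 and 3 carry propyl but also differ at a second site, so steps to them cannot be read.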